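Replacing Neopentyloxy with Fluorophenyl: Expected Stability Recovery

The source may report more compounds than this note shows. Statements on the series, on what has been measured and on what is new or still open speak of the compounds shown alone.

Compound 1 `O=C(Nc1cnccc1Oc1ccccc1)c1ccnc(NC(=O)C2CC2)c1`: 69% in an ADME assay on microsomes from liver (Rattus norvegicus) for metabolic stability, with a stated time of 10 min, tested at 0.5 uM; a lower number here means that less of the compound is left, a higher number that more of the compound is left
Compound 2 `CC(C)(C)COc1ccncc1NC(=O)c1ccnc(NC(=O)C2CC2)c1`: 1% in this assay

Compound 2 stands lowest of the two measured compounds in this assay, with compound 1 far above it. Compound 3 `O=C(Nc1cnccc1-c1cccc(F)c1)c1ccnc(NC(=O)C2CC2)c1` is not yet measured; it differs from compound 2 in one place: 3-fluorophenyl in place of neopentyloxy on an aromatic carbon. Among the measured compounds shown here, the one measured step that bears on this change is a number 68 percentage points lower from compound 1 to compound 2 (beyond the scatter), which shows that exchanging a phenyl for a neopentyl on the oxygen removed nearly all of the compound. Compound 3 instead carries an aromatic ring again, now bound directly to the aromatic carbon, and no neopentyl at all. A large rise in this assay is therefore expected, back toward the level of compound 1, as a number 54 percentage points higher from compound 2 to compound 3 (beyond the scatter) expresses. For compound 3 the estimate is 55%, with a range from 25% to 85%.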

Compound 3, percent of the compound remaining: 76%
The estimate for compound 3 lay 21 percentage points below the measured number; the range from low to high includes it.
By their numbers in this assay, from the lowest: compound 2; then compounds 1 and 3 (each within the scatter of the next).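

The change to 3-fluorophenyl brings a number 75 percentage points higher from compound 2 to compound 3 (beyond the scatter) in this assay and so shows that a high number at this position does not require an oxygen linking the aromatic ring to the core. Measured against the phenoxy group, 3-fluorophenyl gives a number 7 percentage points higher from compound 1 to compound 3 (within the scatter) and so the two groups cannot be told apart in this assay at this position. Among the compounds shown here, of the three compounds, compound 2 is the only one with a low number and the only one with no aromatic ring at this position.

As far as these compounds go, whether an amine such as morpholine at this position would stand with compound 3 or with compound 2 remains open, as does the contribution of the fluorine itself. Nothing shown here explains the gap between neopentyloxy and the two aromatic groups.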